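The source may report more compounds than this note shows. Statements on the series, on what has been measured and on what is new or still open speak of the compounds shown alone.

In a functional assay on the whole organism (brain) with Mus musculus as the target (a lower number here means that less compound is needed, a higher number that more compound is needed for the effect), compound 1 `O=[N+]([O-])c1ccc(CSCc2c[nH]cn2)cc1` gives > 10 mg/kg as a limit of the assay. Compound 2 `COC(=O)c1ccc(OCCc2c[nH]cn2)cc1` gives > 3 mg/kg as a limit too, so it has no measured number. Compound 3 `O=C(c1ccccc1)c1ccc(OCCc2c[nH]cn2)cc1` gives 2.6 mg/kg as a true number. Compound 4 `FC(F)(F)c1ccc(OCCc2c[nH]cn2)cc1` has not yet been tested. It differs from compound 2 by one change trifluoromethyl in place of methoxycarbonyl on an aromatic carbon in which trifluoromethyl stands in place of methoxycarbonyl on an aromatic carbon. Within the data shown here, one measured step touches that same group: an at least 1.1-fold lower number from compound 2 to compound 3 (0.06 log units; that floor lies within the scatter) with phenyl in place of methoxy on a carbonyl carbon. That step is bounded on one side only and its floor lies within the scatter, so it sets no firm size for the new change. No step beyond the scatter is therefore expected in this assay on this evidence. Among the measured compounds shown here, the expectation leans on compound 3 at 2.6 mg/kg as the one true number among the close analogues. The expected step is a number no higher from compound 2 to compound 4 (the limit leaves the size open) and no clear direction is foreseen. For compound 4 the estimated value is 3 mg/kg with an expected range from 1 mg/kg to 10 mg/kg and the assay may again report only a limit.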

Compound 4, dose for half-maximal effect: > 10 mg/kg
Compound 4: only a limit was reported; the forecaster's own chance of this, stated with the estimate: 35%; middle value at least 3.3-fold (0.52 log units) from the limit.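

In this assay compound 4 gives > 10 mg/kg, a limit of the assay. Among these compounds, compound 2 likewise gives only a limit, > 3 mg/kg, so no step between compound 2 and compound 4 can be read. The compounds shown leave open what size of change trifluoromethyl in place of methoxycarbonyl brings.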